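A few compounds are considered here, and "the series" means these few. Any claim that something is new, unique, unknown or untested is made for them only; others in the source may bear on it.

Compound 1 `Cc1c(OCCCCOc2ccccc2C(=O)O)ccc(C(=O)CC(C)C)c1O`: 415 nM. Compound 2 `Cc1c(OCCCCOc2cccc(C(=O)O)c2)ccc(C(=O)CC(C)C)c1C`: "not active" (no number reported). Compound 3 `Cc1c(OCCCCOc2ccc(C(=O)O)cc2)ccc(C(=O)CC(C)C)c1C`: "not determined" (no result reported).

In an assay on HEK293 cells for positive allosteric modulation of metabotropic glutamate receptor 2 (Rattus norvegicus), read by thallium flux, with a stated time of 2.5 min (on this read-out higher numbers stand for an effect only at larger amounts of compound and lower numbers for an effect already at smaller amounts), compound 1 gives 415 nM, while compound 2 is reported as "not active" (no number reported). From the compounds shown here alone, compound 3 stands without a number in this assay, reported as "not determined" (no result reported), so its position on the scale is unknown, and it is one of two compounds here with no single number. Compound 4 `Cc1c(OCCCCOc2ccccc2C(=O)O)ccc(C(=O)CC(C)C)c1C` differs from compound 3 by 2-carboxyphenyl in place of 4-carboxyphenyl on an oxygen on a saturated carbon. For the measured compounds named here, with no measured step between these two, neither the size nor the direction of the change in this assay can be read from the data. Going by the values given here, the only guide is compound 1, which shares the 2-carboxyphenyl group on a different core and gives 415 nM. Compound 4 is expected to give about 700 nM, in a range from 200 nM to 4000 nM.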

Compound 4, half-maximal effective concentration: 976 nM
The estimate for compound 4 lay 1.4-fold (0.14 log units) below the measured number, within the range that was stated.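

In this assay, methyl in place of hydroxy on an aromatic carbon gives a 2.4-fold higher number from compound 1 to compound 4 (0.37 log units; beyond the scatter), a modest step beyond the usual scatter. With 2-carboxyphenyl in place, the core carrying methyl therefore still gives a number, though a higher one than the core carrying hydroxy. The steps from compound 4 to compound 2 and to compound 3 cannot be read. From the compounds shown here alone, whether an amine or a methoxy group on that aromatic carbon would give a number nearer that of compound 1 or compound 4 remains open. Nothing available here explains the step.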